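Benzyl for cyclopropylmethyl on the ring nitrogen

The compounds below may be only part of what the source reports. "The series", "measured", "known", "first", "only" and "open" are said of these compounds alone.

Measured so far in an ADME assay on Huh-7 cells (Homo sapiens) for cytotoxicity; a lower number here means a stronger inhibitor of growth, a higher number a weaker inhibitor of growth:
compound 1 `COc1cc2c(=O)c(C(=O)c3ccc(C)cc3)cn(CC3CC3)c2cc1OC`: "not active" (no number reported)
compound 2 `O=C(OCc1ccc(Cl)cc1)c1cn(Cc2ccc(Cl)cc2)c2cc(N3CCNCC3)c(F)cc2c1=O`: 1100 nM
compound 3 `COc1cc2c(=O)c(S(=O)(=O)CCc3ccc(Cl)cc3)cn(Cc3ccccc3)c2cc1OC`: "not active" (no number reported)

Compound 1 has no single number in this assay; it is reported as not active, and the same holds for compound 3, so no ranking among these two is possible. Going by the values given here, compound 2 is the only member of the series with a reported concentration for growth inhibition, and it carries a different substitution pattern on the shared core, so it gives no direct reference for compound 1.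

The unmeasured compound 4 `COc1cc2c(=O)c(C(=O)c3ccc(C)cc3)cn(Cc3ccccc3)c2cc1OC` keeps the core of compound 1 and differs in one place: phenyl in place of cyclopropyl on a saturated chain carbon bound to an aromatic nitrogen. Compound 3 already carries a benzyl group on the same aromatic nitrogen and is not active in this assay, which gives some ground for the expectation that compound 4 will stay weak as well. Among the compounds with values here, no step between measured compounds with this difference exists, so no measured size can be quoted for it; the expectation is for no change beyond the scatter, meaning compound 4 most likely also returns no number in this assay.

For compound 4 the estimated concentration in this assay, should a number be obtained, is 30000 nM, within 8000 nM to 120000 nM.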

Compound 4, concentration for 50% growth inhibition: "not active" (no number reported)
Compound 4 has no reported number here, and the estimate cannot be compared.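

In this assay, going by these compounds alone, compound 1 gives "not active" (no number reported) and compound 4 gives "not active" (no number reported) so no step from cyclopropylmethyl to benzyl can be read. The compounds shown leave open whether this change alters growth inhibition on the shared core at all. No supporting measurement bears on this result.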